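From piperidin-1-yl to benzylamino on a carbonyl carbon

The compounds below may be only part of what the source reports. "The series", "measured", "known", "first", "only" and "open" are said of these compounds alone.

In a functional assay on HL-60 cells (Homo sapiens) for antiproliferative activity, read by MTT assay, with a stated time of 24 h (on this read-out higher numbers stand for weaker inhibition and lower numbers for stronger inhibition), compound 3 (`CCCCc1oc2ccccc2c1C(=O)c1ccc(OCCCC(=O)N2CCCCC2)cc1`) gives 31900 nM and compound 2 (`CCCCc1oc2ccccc2c1C(=O)c1ccc(OCCCC(=O)N2CCCC2)cc1`) gives 29900 nM, two values within the scatter of each other. Compound 1 (`CCCCc1oc2ccccc2c1C(=O)c1ccc(OCC(=O)N2CCCCC2)cc1`) reads > 50000 nM, which is a limit of the assay and not a number.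

Compound 4 (`CCCCc1oc2ccccc2c1C(=O)c1ccc(OCCCC(=O)NCc2ccccc2)cc1`) has benzylamino in place of piperidin-1-yl on a carbonyl carbon. The closest measured change at that carbon, a 1.1-fold higher number from compound 2 to compound 3 (0.03 log units; within the scatter), stayed within the scatter, but it did not involve benzylamino. Among the measured compounds shown here, no measured compound carries that group, so the expectation is weakly supported. The expected step is small, a 1.1-fold lower number from compound 3 to compound 4 (0.06 log units; within the scatter), with no direction beyond the scatter. For compound 4 the estimated value in this assay is 28000 nM, with an expected range of 12000 nM to 50000 nM.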

Compound 4, half-maximal inhibitory concentration: 28900 nM
Compound 4: the middle estimate sits 1.0-fold (0.01 log units) below what was measured, within the range that was stated.
By their numbers in this assay, from the lowest: compounds 4, 2 and 3 (each within the scatter of the next). At a limit, above all of these: compound 1.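

In this assay, the step of a 1.1-fold lower number from compound 3 to compound 4 (0.04 log units; within the scatter) and the step of a 1.0-fold lower number from compound 2 to compound 4 (0.01 log units; within the scatter) both stay within the scatter. At this carbonyl carbon, then, benzylamino, with its aromatic ring and amide hydrogen, reads alike with the two saturated rings of compound 2 and compound 3. Nothing given here offers a reason for this sameness.

Still open, going by these compounds, is whether a carboxylic acid in place of these amides would separate from this group of values. So is whether benzylamino on the shorter chain of compound 1 would read like compound 4.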